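From Pyridin-2-yl to 3-Chlorophenyl: One Aryl Swap

A few compounds are considered here, and "the series" means these few. Any claim that something is new, unique, unknown or untested is made for them only; others in the source may bear on it.

Measured in a functional assay on DU-145 cells (Homo sapiens) for cytotoxicity, in the presence of a further agent that is not named here; on this read-out lower numbers stand for stronger inhibition and higher numbers for weaker inhibition:
compound 1, `Cc1ccc(-c2cc(-c3ccc(Cl)o3)cc(-c3ccsc3)n2)o1`, gives 18500 nM
compound 2, `Cc1cccc(-c2cc(-c3ccc(Cl)o3)cc(-c3ccsc3)n2)c1`, gives 17900 nM
compound 3, `Clc1ccc(-c2cc(-c3ccsc3)nc(-c3ccccn3)c2)o1`, gives 10900 nM

Compound 3 has the lowest number of the three, but its gaps to the others, a 1.7-fold lower number from compound 1 to compound 3 (0.23 log units; within the scatter) and a 1.6-fold lower number from compound 2 to compound 3 (0.22 log units; within the scatter), are within the scatter, so the three cannot be ranked. Compound 4, `Clc1cccc(-c2cc(-c3ccc(Cl)o3)cc(-c3ccsc3)n2)c1`, has not yet been measured in this assay. It differs from compound 3 in one place: 3-chlorophenyl in place of pyridin-2-yl on an aromatic carbon.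

Going by the values given here, the steps that bear on this are those that already vary the same position: the change from compound 1 to compound 2, a 1.0-fold lower number from compound 1 to compound 2 (0.01 log units; within the scatter), and the two steps into compound 3 just named. All three are within the scatter, so this position has so far tolerated a five-membered ring, a carbon-only six-membered ring and a six-membered ring holding one nitrogen without a clear shift. A 3-chlorophenyl group is therefore expected to give a number close to that of compound 3, with no step beyond the scatter: a 1.4-fold higher number from compound 3 to compound 4 (0.14 log units; within the scatter). Compound 4 is estimated at 15000 nM, within a range of 7000 nM to 32000 nM.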

Compound 4, half-maximal inhibitory concentration: 10400 nM
Beside the measured number, compound 4's estimate is 1.4-fold (0.16 log units) above it; measured number inside the range.
By their numbers in this assay, from the lowest: compounds 4, 3, 2 and 1 (each within the scatter of the next).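

In this assay the swap of the ring holding a nitrogen for one of carbon only, which also brings a chlorine and removes the hydrogen-bond acceptor counted on pyridin-2-yl, gives no clear shift (a 1.0-fold lower number from compound 3 to compound 4 (0.02 log units; within the scatter)). Exchanging only the small group on the carbon-only ring, chloro in place of methyl, also stays within the scatter (a 1.7-fold lower number from compound 2 to compound 4 (0.24 log units; within the scatter)), as does the wider exchange of 5-methylfuran-2-yl for 3-chlorophenyl (a 1.8-fold lower number from compound 1 to compound 4 (0.25 log units; within the scatter)). No independent measurement is available to explain why these changes make so little difference.

On these data alone, whether this position would accept something other than an aromatic ring, such as an amine, a carboxylic acid or a longer chain, remains open. Also open, as far as these compounds go, is whether changing the 5-chlorofuran-2-yl or thiophen-3-yl group would produce a step beyond the scatter.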